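Benzylamino in Place of a Selenium Chain on Compound 2

This account rests on a few compounds, and the source may have more. Where it says the series, first, only, none or still open, it means among the compounds named here.

In a functional assay on HT-29 cells (Homo sapiens) for cytotoxicity, read by MTT assay, with a stated time of 72 h (a higher number here means that more compound is tolerated, a lower number that less compound is tolerated), compound 2 `CCCCC[Se]c1nc([Se]CCCCC)c2ccccc2n1` reaches only the limit of the assay, > 100000 nM, and not a number. Compound 1 `COc1ccc(CNc2nc([Se]C)nc3ccccc23)cc1` also sits at the limit, > 100000 nM. Compound 3 `CSc1nc(NCCCc2ccccc2)c2ccccc2n1` likewise gives only the limit, > 100000 nM. Within the data shown here, all three values thus rest on (the limit of > 100000 nM in this assay, at which 3 of the 3 values shown sit), so no step between measured compounds can be sized. Compound 4 `CCCCC[Se]c1nc(NCc2ccccc2)c2ccccc2n1` differs from compound 2 by a group of 8 heavy atoms (7 carbon, 1 nitrogen; one six-membered aromatic ring of carbon only) in place of a group of 6 heavy atoms (5 carbon, 1 selenium; no ring), on an aromatic carbon, the entering benzylamino sitting next to the ring nitrogen and ortho to a fused ring. Compound 1 and compound 3 already pair the shared core with an amino substituent and sit at the limit of > 100000 nM in this assay, at which 3 of the 3 values shown sit, so no step beyond the scatter in either direction is expected in this assay. The step of a number no higher from compound 2 to compound 4 (the limit leaves the size open) is expected to be about nothing. Compound 4 is estimated at 100000 nM, with a range from 40000 nM to 250000 nM.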

Compound 4, concentration lethal to 50% of the cells: > 100000 nM
Compound 4: only a limit was reported; the forecaster's own chance of this, stated with the estimate: 80%; the middle value lies on the limit itself.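

Among these compounds, compound 2 and compound 4 both give only a limit, so no step between them can be read: the limit of > 100000 nM in this assay, at which 4 of the 4 values shown sit. As far as these compounds go, how compound 1, compound 2, compound 3 and compound 4 compare beyond that limit stays open.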